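The source may hold more compounds than are shown below. What is called first, only, known or untested is meant among the compounds shown, and "the series" means these compounds.

Measured so far in a functional assay on MDA-MB-231 cells (Homo sapiens) for antiproliferative activity, read by sulforhodamine B assay, with a stated time of 72 h; on this read-out higher numbers stand for weaker inhibition and lower numbers for stronger inhibition:
- Compound 1 `COc1c(OC(C)C)cc2occ(-c3csc4ccccc34)c(=O)c2c1OC(C)C` gives > 10000 nM as a limit
- Compound 2 `COc1c(OC(C)C)cc2occ(-c3csc4ccccc34)c(=O)c2c1O` gives > 10000 nM as a limit

Compound 2 stands at > 10000 nM in this assay, which is a limit of the assay and not a number. Among the measured compounds shown here, the one further value, that of compound 1, is also a limit.

Compound 3 `COc1c(O)cc2occ(-c3csc4ccccc34)c(=O)c2c1O` has not yet been measured. It has hydrogen in place of isopropyl on an oxygen on an aromatic ring, an isopropoxy to hydroxy change, with the difference from compound 2 counted as hydrogen in place of isopropyl on an oxygen on an aromatic ring here.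

The same kind of change has one measured precedent, a step that the two limits leave unreadable from compound 1 to compound 2 in this case. All the available evidence is the limit of > 10000 nM in this assay, at which 2 of the 2 values shown sit, in summary. That precedent therefore offers neither a size nor a direction for the new change, so no step beyond the usual scatter is expected, and a second limit is a likely result. The expected change is an estimated a number no higher from compound 2 to compound 3 (the limit leaves the size open) overall. Compound 3 is expected near 10000 nM as a central estimate. The estimated range for compound 3 runs from 3000 nM to 30000 nM in this assay.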

Compound 3, half-maximal inhibitory concentration: > 10000 nM
Compound 3: a limit, no number (the forecaster's own chance of this, stated with the estimate: 65%); the middle value lies on the limit itself.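

Compound 3 also gives a limit of the assay and not a number, so the step from compound 2 to compound 3 cannot be read, just like the earlier step from compound 1 to compound 2. The compounds shown leave open whether hydrogen in place of isopropyl changes inhibition at all, and how strongly any of them inhibits, with one reading for all: the limit of > 10000 nM in this assay, at which 3 of the 3 values shown sit.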